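A methoxy group replaces a nitro group

This account rests on a few compounds, and the source may have more. Where it says the series, first, only, none or still open, it means among the compounds named here.

Measured in a functional assay on HL-60 cells (Homo sapiens) for antiproliferative activity; a higher number here means a weaker inhibitor, a lower number a stronger inhibitor:
compound 1 `COc1ccc(-c2snnc2-c2cc(OC)c(OC)c(OC)c2)cc1[N+](=O)[O-]`: 13.4 nM
compound 2 `COc1cc(-c2nnsc2-c2ccc([N+](=O)[O-])cc2)cc(OC)c1OC`: > 1000 nM

Two compounds set the scene, and only one of them has an exact number. Compound 2 gives > 1000 nM, which is a limit of the assay and not a number. Its place on the scale is therefore known only as the limit of > 1000 nM in this assay, at which 1 of the 2 values shown sits.

Compound 3 `COc1ccc(-c2snnc2-c2cc(OC)c(OC)c(OC)c2)cc1` has not yet been measured. It differs from compound 2 in a single place: methoxy in place of nitro on an aromatic carbon. This puts methoxy in place of nitro on an aromatic carbon, para to a large group.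

Among the measured compounds shown here, no measured pair shows this change alone, so the size of the step is a judgement. A large move towards stronger inhibition, meaning a lower number in this assay, is expected. Compound 3 shares a methoxy group with compound 1, which gives 13.4 nM. The expected change is an at least 33-fold lower number from compound 2 to compound 3 (1.52 log units; beyond the scatter). For compound 3 the estimated value is 30 nM, with an expected range from 6 nM to 200 nM.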

Compound 3, half-maximal inhibitory concentration: 14.5 nM
Estimate against measurement, compound 3: 2.1-fold (0.32 log units) above, and the stated range covers the measured number.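

Placing methoxy where compound 2 carries nitro, para to a large group, gives an at least 68-fold lower number from compound 2 to compound 3 (1.83 log units; beyond the scatter) in this assay, so the group at this position on the aromatic ring makes a large difference to the result. Compound 2 gives only a limit of the assay and not a number, so this step has a lower bound but no exact size: the limit of > 1000 nM in this assay, at which 1 of the 3 values shown sits. The nitro group of compound 1 makes no difference that can be read once methoxy is in place: with hydrogen in its place there is a 1.1-fold higher number from compound 1 to compound 3 (0.03 log units; within the scatter), so that nitro group is not needed to reach this level of activity in this assay.

The compounds shown leave open whether methoxy itself is required at this position, or whether another group, such as an ethoxy group, an amine or a chlorine atom, would serve as well. All three compounds also carry the rest of the core unchanged, so what those parts contribute to the activity remains an open question.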